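This account rests on a few compounds, and the source may have more. Where it says the series, first, only, none or still open, it means among the compounds named here.

Three compounds have been measured in a functional assay on 786-0 cells (Homo sapiens) for cytotoxicity, read by sulforhodamine B assay, with a stated time of 48 h; a lower number here means a stronger inhibitor of growth, a higher number a weaker inhibitor of growth:

Compound 1, `ClCc1cccc(Cn2cnc3c(Cl)ncnc32)c1`, gives 6160 nM.
Compound 2, `ClCc1cccc(Cn2cnc3c(Cl)nc(Cl)nc32)c1`, gives 12300 nM.
Compound 3, `ClCc1ccccc1Cn1cnc2ncnc(Cl)c21`, gives 3980 nM.

Compound 1 and compound 2 share one core and differ in a single place: chloro in place of hydrogen on an aromatic carbon. In this assay this change made a 2.0-fold higher number from compound 1 to compound 2 (0.30 log units; within the scatter). Compound 3 is built from the same atoms as compound 1, joined differently; the difference between the two cores is not broken down here. In this assay compound 3 stands within the scatter of compound 1, while its gap to compound 2 lies beyond the scatter.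

Compound 4, `ClCc1ccccc1Cn1cnc2nc(Cl)nc(Cl)c21`, has not yet been measured in this assay. It differs from compound 3 by the same change as that seen between compound 1 and compound 2: chloro in place of hydrogen on an aromatic carbon. The expectation for compound 4 rests on that matching change, which gave a 2.0-fold higher number from compound 1 to compound 2 (0.30 log units; within the scatter). For compound 4 the expected step is therefore a 2.0-fold higher number from compound 3 to compound 4 (0.30 log units; within the scatter). Compound 4 is thus estimated to give about 8000 nM in this assay, most likely between 4000 nM and 16000 nM.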

Compound 4, concentration for 50% growth inhibition: 2630 nM
For compound 4 the middle estimate is 3.0-fold (0.48 log units) above the measured one; the measured number lies below the stated range.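

In this assay, chloro in place of hydrogen on the aromatic carbon between two ring nitrogen atoms gave a 1.5-fold lower number from compound 3 to compound 4 (0.18 log units; within the scatter), so the step seen on the core of compound 1 did not carry over to the core of compound 3: the same change on two cores in this assay, a 2.0-fold higher number (0.30 log units; within the scatter) from compound 1 to compound 2 and a 1.5-fold lower number (0.18 log units; within the scatter) from compound 3 to compound 4, 3.0-fold (0.48 log units) apart, beyond the scatter of two such steps. Each step alone lies within the scatter, so neither pair shows on its own that this chloro group changes growth inhibition; only the gap between the two steps lies beyond it. With a single pair on each core, this shows that the step on one core could not be used to set a number on the other here, but it does not show why the two steps differ or how the change would behave on a further core.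

The compounds shown leave open whether an amine or a methoxy group on that same aromatic carbon would give a step beyond the scatter on either core. They also leave open how these numbers would stand if a plain methyl group took the place of the chloromethyl group.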